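Moving two chlorines: from compound 3 to compound 4

The source may hold more compounds than are shown below. What is called first, only, known or untested is meant among the compounds shown, and "the series" means these compounds.

- compound 1 `COc1cc(C(=O)/C=C/c2c(Cl)cccc2Cl)cc(OC)c1OC` gives 50500 nM
- compound 2 `COc1cc(C(=O)/C=C/c2ccc(C)o2)cc(OC)c1OC` gives 46500 nM
- compound 3 `COc1cc(C(=O)/C=C/c2ccc(Cl)cc2Cl)cc(OC)c1OC` gives 52500 nM

In a functional assay on L1210 cells (Mus musculus) for cytotoxicity, read by MTT assay, with a stated time of 24 h (on this read-out lower numbers stand for stronger inhibition and higher numbers for weaker inhibition), compound 3 gives 52500 nM and sits within the scatter of both other compounds, so the three cannot be ranked. Compound 4 `COc1cc(C(=O)/C=C/c2cc(Cl)cc(Cl)c2)cc(OC)c1OC` has the same atoms as compound 3, joined differently: 3,5-dichlorophenyl in place of 2,4-dichlorophenyl on a double-bonded chain carbon bound to a double-bonded chain carbon with 3,5-dichlorophenyl in place of 2,4-dichlorophenyl on a double-bonded chain carbon bound to a double-bonded chain carbon.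

The closest guide is a 1.0-fold higher number from compound 1 to compound 3 (0.02 log units; within the scatter) where 2,4-dichlorophenyl replaces 2,6-dichlorophenyl. Two wider swaps, a 1.1-fold lower number from compound 1 to compound 2 (0.04 log units; within the scatter) and a 1.1-fold higher number from compound 2 to compound 3 (0.05 log units; within the scatter) also stayed within the scatter. Among the measured compounds shown here, none of the measured compounds carries 3,5-dichlorophenyl, so this guide is indirect. No shift beyond the scatter is therefore expected in this assay and the expected size is a 1.1-fold lower number from compound 3 to compound 4 (0.04 log units; within the scatter) in this estimate. For compound 4 the estimated value is 48000 nM with an expected range from 24000 nM to 90000 nM around it.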

Compound 4, half-maximal inhibitory concentration: 44000 nM
Estimate against measurement, compound 4: 1.1-fold (0.04 log units) above; low and high end bracket the measured number.
By their numbers in this assay, from the lowest: compounds 4, 2, 1 and 3 (each within the scatter of the next).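

In this assay the two chlorines can be rearranged on the phenyl ring with no readable effect: 3,5-dichlorophenyl in place of 2,4-dichlorophenyl gives a 1.2-fold lower number from compound 3 to compound 4 (0.08 log units; within the scatter) and so adds a third chlorine pattern to the comparison. The new group also cannot be separated from the other two groups, with a 1.1-fold lower number from compound 1 to compound 4 (0.06 log units; within the scatter) where it replaces 2,6-dichlorophenyl and a 1.1-fold lower number from compound 2 to compound 4 (0.02 log units; within the scatter) where it replaces 5-methylfuran-2-yl. Across these four compounds, then, the three dichlorophenyl patterns and 5-methylfuran-2-yl all read alike at this place, on a double-bonded chain carbon bound to a double-bonded chain carbon.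

Nothing available explains why these groups read alike. From the compounds shown here alone, whether a phenyl ring carrying an amine or a carboxylic acid at this place would give a step beyond the scatter remains open.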